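Benzyloxy-bearing enones: one aryl swap, moderate inhibition expected

This account rests on a few compounds, and the source may have more. Where it says the series, first, only, none or still open, it means among the compounds named here.

Measured compounds and their values in a functional assay on HCT-116 cells (Homo sapiens) for antiproliferative activity, read by sulforhodamine B assay, with a stated time of 3 days, tested at 25 uM; on this read-out lower numbers stand for a weaker effect and higher numbers for a stronger effect at the one concentration tested:
Compound 1 `O=C(/C=C/c1ccccc1Cl)c1ccc(OCc2ccccc2)cc1` gives 54.5%.
Compound 2 `O=C(/C=C/c1cccc([N+](=O)[O-])c1)c1ccccc1` gives 100%.
Compound 3 `O=C(/C=C/c1ccc(OCc2ccccc2)cc1)c1ccccc1` gives 52.3%.

Compound 1 stands second highest of the three numbers in this assay. Its nearest neighbour is compound 3, whose number is lower by an amount that lies within the usual scatter, so the two cannot be told apart. The furthest is compound 2, whose number is higher by a margin well beyond the scatter.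

The unmeasured compound 4 `COc1cccc(/C=C/C(=O)c2ccc(OCc3ccccc3)cc2)c1` keeps the shared core of compound 1 and differs from it in one place:
3-methoxyphenyl in place of 2-chlorophenyl on a double-bonded chain carbon bound to a double-bonded chain carbon

For the measured compounds named here, no step between measured compounds that differ in only this place is available, so the size of the change cannot be read from the data. The closest guidance is that compound 1 and compound 3 sit together, while compound 2 stands apart. Compound 4 is expected to remain in the middle range, with a step of a number 6.5 percentage points lower from compound 1 to compound 4 (within the scatter) that is not beyond the scatter. Compound 4 is therefore estimated at 48%, within a range of 20% to 75%.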

Compound 4, a percentage reported as inhibition, at one concentration (the size of the read-out at that concentration, not a potency): 35.4%
Estimate against measurement, compound 4: 12.6 percentage points above; low and high end bracket the measured number.
By their numbers in this assay, from the lowest: compound 4; then compounds 3 and 1 (each within the scatter of the next); then compound 2.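

In this assay, for the compounds shown here, the swap of 2-chlorophenyl for 3-methoxyphenyl on a double-bonded chain carbon bound to a double-bonded chain carbon gives a number 19.1 percentage points lower from compound 1 to compound 4 (beyond the scatter) and thereby provides the first direct reading at this place. The earlier compounds shown here offered no pair differing only here, so they could not show that the group held at this place alters the inhibition reached on the shared core of compound 1. Nothing available accounts for the size or direction of this step.

One step cannot separate what the departure of 2-chlorophenyl contributes from what the arrival of 3-methoxyphenyl contributes. On these data alone, how an aminophenyl or a carboxyphenyl group at the same place would compare with these two remains open, as does whether this step would carry over to a different core.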